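Anilino replacement on the shared core: compound 4 outlook

A few compounds are considered here, and "the series" means these few. Any claim that something is new, unique, unknown or untested is made for them only; others in the source may bear on it.

Measured compounds:
compound 1 `FC(F)(F)c1ccc(CSc2nc(Nc3ccccc3C(F)(F)F)c3ccccc3n2)cc1`; in a functional assay on HGC-27 cells (Homo sapiens) for cytotoxicity, read by MTT assay, with a stated time of 72 h (on this read-out lower numbers stand for stronger inhibition and higher numbers for weaker inhibition), compound 1 gives > 50000 nM, a limit of the assay.
compound 2 `FC(F)(F)c1ccc(CSc2nc(Nc3ccccc3Cl)c3ccccc3n2)cc1`; compound 2 gives > 50000 nM, also a limit.
compound 3 `Fc1ccc(Nc2nc(SCc3ccc(C(F)(F)F)cc3)nc3ccccc23)cc1`; compound 3 gives 19500 nM.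

Compound 1 sits at the limit, as does one other compound (the limit of > 50000 nM in this assay, at which 2 of the 3 values shown sit), so only a bound is known for it and its true number could lie anywhere beyond that bound. Compound 4 `Fc1ccc(Nc2nc(SCc3ccc(C(F)(F)F)cc3)nc3ccccc23)cc1Cl` differs from compound 1 by 3-chloro-4-fluorophenyl in place of 2-(trifluoromethyl)phenyl on a nitrogen on an aromatic ring.

The measured steps that bear on this change are the two replacements giving 4-fluorophenyl: an at least 2.5-fold lower number from compound 1 to compound 3 (0.40 log units; beyond the scatter) and an at least 2.5-fold lower number from compound 2 to compound 3 (0.40 log units; beyond the scatter). Both read as at least modest and both point downward. Among the measured compounds shown here, compound 4 carries 4-fluorophenyl with a chloro added, and no measured pair shows what that added chloro does on its own; the expectation therefore rests on compound 3 alone, with the added chloro treated as neutral.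

The step from compound 1 to compound 4 is expected to be downward, of size an at least 3.3-fold lower number from compound 1 to compound 4 (0.52 log units; beyond the scatter). Compound 4 is expected to give about 15000 nM, estimated to fall between 5000 nM and 50000 nM, with some chance that only a limit is returned.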

Compound 4, half-maximal inhibitory concentration: 14700 nM
Compound 4: the middle estimate sits 1.0-fold (0.01 log units) above what was measured; the measured number falls inside the stated range.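

Working notes on the anilino position: in this assay, a 1.3-fold lower number from compound 3 to compound 4 (0.12 log units; within the scatter), so chloro in place of hydrogen on the 4-fluorophenyl ring gives no readable change. With 3-chloro-4-fluorophenyl on the nitrogen, the replacement of the two earlier groups still reads beyond the scatter: an at least 3.4-fold lower number from compound 1 to compound 4 (0.53 log units; beyond the scatter) and an at least 3.4-fold lower number from compound 2 to compound 4 (0.53 log units; beyond the scatter). Compound 1 and compound 2 each stand at a limit, so these two steps give only a minimum size and the true gaps stay unknown: the limit of > 50000 nM in this assay, at which 2 of the 4 values shown sit.

The compounds shown leave open whether the separation follows the loss of 2-(trifluoromethyl)phenyl and 2-chlorophenyl or the presence of the fluoro carried by compound 3 and compound 4, since those groups change together in every readable step. From the compounds shown here alone, how a plain phenyl, or a phenyl carrying an amine or a carboxylic acid, would read on this nitrogen also stays open, as does whether any group here can bring the number well clear of the values of compound 3 and compound 4.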